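This account rests on a few compounds, and the source may have more. Where it says the series, first, only, none or still open, it means among the compounds named here.

Measured so far:
- compound 1 `COc1ccc(/C(Cl)=C/C=C(\C#N)C(=O)c2c(C)[nH]c3ccccc23)cc1`: "not determined" (no result reported)
- compound 2 `COc1cc(/C(Cl)=C/C=C(\C#N)C(=O)c2c[nH]c3ccc(Br)cc23)cc(OC)c1OC`: 7600 nM
- compound 3 `COc1ccc(/C(Cl)=C/C=C(\C#N)C(=O)c2c[nH]c3ccccc23)cc1`: "not determined" (no result reported)

Among the compounds with values here, in an ADME assay on Vero cells (Chlorocebus sabaeus) for cytotoxicity, read by sulforhodamine B assay, with a stated time of 48 h (on this read-out higher numbers stand for weaker inhibition of growth and lower numbers for stronger inhibition of growth), compound 2 gives 7600 nM; this is the only number in the set. Compound 1 has no result in this assay, and compound 3 has none either, so compound 1 cannot be placed against any other member on the numbers shown: it stands without a value, alongside one further compound without a value.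

The step considered goes from compound 1 to compound 4 `COc1ccc(/C(Cl)=C/C=C(\C#N)C(=O)c2c(C)[nH]c3ccccc23)cc1OC`. The change is methoxy in place of hydrogen on an aromatic carbon. Within the data shown here, no step between measured compounds exists against which the size of this change could be weighed, and the one number available, that of compound 2, belongs to a compound that differs from both compound 1 and compound 4 in more than one place. Among the measured compounds shown here, the expectation for the step is therefore no movement beyond the scatter in this assay, in no particular direction, the whole of it resting on the single value of compound 2.

Compound 4 is expected to give about 8000 nM in this assay, with a range from 2000 nM to 30000 nM.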

Compound 4, concentration for 50% growth inhibition: 11800 nM
Beside the measured number, compound 4's estimate is 1.5-fold (0.17 log units) below it; low and high end bracket the measured number.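

In this assay, within the data shown here, compound 4 gives 11800 nM, while compound 1 has no number, so no step from compound 1 to compound 4 can be read. The compounds shown leave open what methoxy in place of hydrogen at this place does to the read-out in this assay. No supporting evidence bears on this result.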